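A few compounds are considered here, and "the series" means these few. Any claim that something is new, unique, unknown or untested is made for them only; others in the source may bear on it.

Compound 1 `C#CCNC(=O)/C=C/c1c(/C=C/c2ccc(OC)cc2)cc(OC)cc1OC` gives 6930 nM in a functional assay on A549 cells (Homo sapiens) for inhibition, read by MTT assay, with a stated time of 48 h; a lower number here means a stronger inhibitor, a higher number a weaker inhibitor; compound 2 `COc1ccc(/C=C/c2cc(OC)cc(OC)c2/C=C/C(=O)NC(C)C)cc1` gives 2360 nM; compound 3 `CCCCN(CCCC)C(=O)/C=C/c1c(/C=C/c2ccc(OC)cc2)cc(OC)cc1OC` gives 6160 nM.

Among these three, compound 3 stands second highest in this assay. The step of a 1.1-fold lower number from compound 1 to compound 3 (0.05 log units; within the scatter) lies within the scatter, whereas the step of a 2.6-fold higher number from compound 2 to compound 3 (0.42 log units; beyond the scatter) is a modest rise. Compound 4 `CCNC(=O)/C=C/c1c(/C=C/c2ccc(OC)cc2)cc(OC)cc1OC` differs from compound 3 in one place: ethylamino in place of dibutylamino on a carbonyl carbon. The two steps that bear on this are those that replace dibutylamino with a small monoalkylamino group: the step from compound 3 to compound 1 was flat, the step from compound 3 to compound 2 was a modest fall. The ethylamino group sits between those two cases, so a small fall, or none beyond the scatter, is expected in this assay. Compound 4 is therefore estimated at 4000 nM, with a range of 1800 nM to 9000 nM, an expected step of a 1.5-fold lower number from compound 3 to compound 4 (0.19 log units; within the scatter).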

Compound 4, half-maximal inhibitory concentration: 7860 nM
For compound 4 the middle estimate is 2.0-fold (0.29 log units) below the measured one, and the stated range covers the measured number.
By their numbers in this assay, from the lowest: compound 2; then compounds 3, 1 and 4 (each within the scatter of the next).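

In this assay, ethylamino in place of dibutylamino gives a 1.3-fold higher number from compound 3 to compound 4 (0.11 log units; within the scatter), and methyl in place of ethynyl gives a 1.1-fold higher number from compound 1 to compound 4 (0.05 log units; within the scatter), so neither change moves the number beyond the scatter. A single methyl on the saturated chain carbon bound to the amide-type nitrogen does separate compound 2 from compound 4, with hydrogen in its place giving a 3.3-fold higher number from compound 2 to compound 4 (0.52 log units; beyond the scatter), which makes isopropylamino the one group shown that stands apart. No evidence shown accounts for this difference.

The compounds shown leave open how tert-butylamino, cyclopropylamino or morpholine on the carbonyl carbon would compare with isopropylamino in this assay.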